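A few compounds are considered here, and "the series" means these few. Any claim that something is new, unique, unknown or untested is made for them only; others in the source may bear on it.

In a functional assay on A-431 cells (Homo sapiens) for antiproliferative activity, read by MTT assay, with a stated time of 72 h (on this read-out higher numbers stand for weaker inhibition and lower numbers for stronger inhibition), compound 1 (`COc1cc2ncnc(Nc3ccc(F)c(Br)c3)c2cc1OCCCN1CCNCCNCCNCC1`) gives 1580 nM, compound 2 (`COc1cc2ncnc(Nc3cccc(Br)c3)c2cc1OCCCN1CCNCCNCC1`) gives 2320 nM, and compound 3 (`COc1cc2ncnc(Nc3ccc(Br)cc3F)c2cc1OCCCN1CCNCCNCC1`) gives 561 nM, the lowest of the three numbers. Compound 4 (`COc1cc2ncnc(Nc3ccc(F)c(Br)c3)c2cc1OCCCN1CCNCCNCC1`) has the same atoms as compound 3, joined differently: 3-bromo-4-fluorophenyl in place of 4-bromo-2-fluorophenyl on a nitrogen on an aromatic ring. Among the compounds with values here, one measured step bears directly on this change. It is a 4.1-fold lower number from compound 2 to compound 3 (0.62 log units; beyond the scatter), in which 4-bromo-2-fluorophenyl took the place of 3-bromophenyl on a nitrogen on an aromatic ring, and it lies beyond the scatter. Compound 4 gives up that 4-bromo-2-fluorophenyl group. The 3-bromo-4-fluorophenyl group that enters is already carried by compound 1, at 1580 nM, although the rest of that structure differs. Much of the drop seen in the measured step is therefore expected to be lost. A modest step toward a higher number, a 2.5-fold higher number from compound 3 to compound 4 (0.40 log units; beyond the scatter), is expected in this assay, beyond the scatter. The estimate for compound 4 is 1400 nM, with an expected range of 600 nM to 3000 nM.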

Compound 4, half-maximal inhibitory concentration: 1060 nM
The estimate for compound 4 lay 1.3-fold (0.12 log units) above the measured number, and the stated range covers the measured number.
By their numbers in this assay, from the lowest: compounds 3, 4, 1 and 2 (each within the scatter of the next, the first and the last beyond it).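

In this assay the two arrangements of the same atoms on the aromatic nitrogen are not separated: 3-bromo-4-fluorophenyl in place of 4-bromo-2-fluorophenyl gives a 1.9-fold higher number from compound 3 to compound 4 (0.28 log units; within the scatter) and so leaves no firm preference between them. Fluoro in place of hydrogen on an aromatic carbon of the 3-bromophenyl group gives a 2.2-fold lower number from compound 2 to compound 4 (0.34 log units; beyond the scatter) and so, like the change to compound 3, moves the number beyond the scatter. With the 3-bromo-4-fluorophenyl group held constant, the nine-membered ring in place of the larger ring of compound 1 gives a 1.5-fold lower number from compound 1 to compound 4 (0.17 log units; within the scatter) and so does not separate the two ring sizes.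

No evidence given here accounts for these steps. Still open, from the compounds shown here alone, is whether chloro in place of the bromo, or an open-chain amine in place of the nine-membered ring, would shift the number beyond the scatter.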